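The source may report more compounds than this note shows. Statements on the series, on what has been measured and on what is new or still open speak of the compounds shown alone.

Working notes on the series.

Going by the values given here, compound 2, with the structure `CCOC(=O)CCCCCOc1cccc(CN(C(=O)c2ccc(-c3ccc4ccccc4c3)cc2)C(C)C)c1`, is one of two compounds measured so far in an ADME assay on HepG2 cells (Homo sapiens) for cytotoxicity, read by CellTiter-Glo and resazurin assay, with a stated time of 72 h; a lower number here means that less compound is needed, a higher number that more compound is needed for the effect. In this assay compound 2 reaches only the limit of the assay, > 26000 nM, and not a number. Compound 1, with the structure `CC(C)N(Cc1cccc(OCCCCCC(=O)O)c1)C(=O)c1ccc(-c2cccc(OCc3ccccc3)c2)cc1`, likewise sits at the limit of this assay, > 26000 nM, and not at a number. Among the compounds with values here, both values thus stand at the limit of > 26000 nM in this assay, at which 2 of the 2 values shown sit, so the series so far gives no measurable cytotoxicity to compare.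

The next compound to be measured is compound 3, with the structure `CCOC(=O)CCCCCOc1cccc(CN(C(=O)c2ccc(-c3cccc(O)c3)cc2)C(C)C)c1`. It differs from compound 2 in one place: 3-hydroxyphenyl in place of naphthalen-2-yl on an aromatic carbon.

Within the data shown here, no measured step is known, so the size of the step from compound 2 to compound 3 in this assay can only be anticipated. The expectation is that compound 3 again shows no effect within the tested range, with the estimated step that the limit leaves unreadable from compound 2 to compound 3 lying within the scatter. For compound 3 the estimated value in this assay is 30000 nM, with a range from 15000 nM to 80000 nM.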

Compound 3, half-maximal effective concentration: > 26000 nM
Compound 3 gave a limit, no number (the forecaster's own chance of this, stated with the estimate: 80%); the middle value lies beyond the limit too.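

In this assay compound 3 gives > 26000 nM as a limit and not a number, so no step can be read between compound 2 and compound 3: the limit of > 26000 nM in this assay, at which 3 of the 3 values shown sit.

The compounds shown leave open whether 3-hydroxyphenyl in place of naphthalen-2-yl alters cytotoxicity at all.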